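The source may hold more compounds than are shown below. What is called first, only, known or untested is meant among the compounds shown, and "the series" means these compounds.

Measured so far in a functional assay on HepG2 cells (Homo sapiens) for cytotoxicity, read by MTT assay, with a stated time of 48 h; on this read-out lower numbers stand for stronger inhibition and higher numbers for weaker inhibition:
- compound 1 `Cc1n[nH]c2c1C(c1ccc(N(C)C)cc1)C(C(=O)NNC(N)=S)=C(N)N2`: 6320 nM
- compound 2 `Cc1n[nH]c2c1C(c1ccc(N(C)C)cc1)C(C(=O)n1ncc(C#N)c1N)=C(N)N2`: 66300 nM

Compound 2 stands highest of the two numbers; its nearest neighbour is compound 1, which gives a 10-fold higher number from compound 1 to compound 2 (1.02 log units; beyond the scatter). That single step bears on the open question only indirectly: it exchanges one group for another on the carbonyl carbon, whereas compound 3 `Cc1n[nH]c2c1C(c1ccc(N(C)C)cc1)C=C(N)N2` removes the whole (5-amino-4-cyano-1H-pyrazol-1-yl)carbonyl group, (hydrogen in place of (5-amino-4-cyano-1H-pyrazol-1-yl)carbonyl on a double-bonded ring carbon). For the measured compounds named here, no measured pair shows what an unsubstituted double-bonded ring carbon does in this assay. Given that the smaller group of compound 1 sits at the lower number and the larger group of compound 2 at the higher, a lower number than compound 2 is expected for compound 3, though with wide uncertainty, and the expected step is a 3.3-fold lower number from compound 2 to compound 3 (0.52 log units; beyond the scatter). Compound 3 is estimated at 20000 nM in this assay, within 4000 nM to 100000 nM.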

Compound 3, half-maximal inhibitory concentration: 20600 nM
Compound 3: middle estimate off by 1.0-fold (0.01 log units), on the low side, within the range that was stated.
By their numbers in this assay, from the lowest: compound 1; then compound 3; then compound 2.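

In this assay, the double-bonded ring carbon now has a reference with hydrogen alone: losing the (5-amino-4-cyano-1H-pyrazol-1-yl)carbonyl group gives a 3.2-fold lower number from compound 2 to compound 3 (0.51 log units; beyond the scatter) and so places that group on the weaker side of the unsubstituted compound. Hydrogen in place of the open-chain group of compound 1 runs the other way, with a 3.3-fold higher number from compound 1 to compound 3 (0.51 log units; beyond the scatter) on this read-out, so substitution at this carbon does not shift the number in a single direction across these three compounds. Nothing at hand explains why the two groups fall on opposite sides of hydrogen.

Open, going by these compounds, is where a carboxylic acid, a methyl ester or a primary amide on this carbon would fall relative to compound 3. Also open, on these data alone, is whether the same order holds with a 4-chlorophenyl group in place of the 4-(dimethylamino)phenyl group.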